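Alpha-substitution on the anilide-linked chain: efficacy notes

A few compounds are considered here, and "the series" means these few. Any claim that something is new, unique, unknown or untested is made for them only; others in the source may bear on it.

Measured compounds:
compound 1, `C[C@H](C(=O)Nc1nccs1)c1ccc(Cl)cc1`: 83%
compound 2, `O=C(Nc1ncc(F)s1)[C@H](c1ccc(Cl)cc1)C1CC1`: 103%

In a functional assay on CHO cells for agonist activity at Free fatty acid receptor 2 (Homo sapiens), read by cAMP accumulation (on this read-out lower numbers stand for smaller maximal responses and higher numbers for larger maximal responses), compound 1 gives 83%, the lower of the two numbers at hand. Compound 2 in this assay reaches 103%, a value that lies beyond the scatter above compound 1; since compound 2 differs from compound 1 in more than one place, no single step can be read from that pair.

Compound 3, `COCC[C@H](C(=O)Nc1nccs1)c1ccc(Cl)cc1`, is not yet measured. Relative to compound 1 it carries methoxymethyl in place of hydrogen on a saturated chain carbon, two bonds along the chain from an aromatic carbon and a carbonyl carbon. For the measured compounds named here, no measured pair shows what such a change does on this read-out, so the expected step is taken as small: compound 2, which also carries a group on that saturated chain carbon, gives the higher number, but its second difference leaves that hint weak. The step from compound 1 to compound 3 is expected to be a number 9 percentage points higher from compound 1 to compound 3 (within the scatter), upward but close to the scatter. For compound 3 the expected value in this assay is 92%, within a range from 75% to 110%.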

Compound 3, largest response reached (reported as efficacy), in percent of the reference or control that the assay uses: 53%
Compound 3: the middle estimate sits 39 percentage points above what was measured; measured number outside the range, below it.
By their numbers in this assay, from the lowest: compound 3; then compound 1; then compound 2.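

In this assay the saturated chain carbon, two bonds along the chain from an aromatic carbon and a carbonyl carbon, proves sensitive to what it carries: methoxymethyl in place of hydrogen gives a number 30 percentage points lower from compound 1 to compound 3 (beyond the scatter) on the core of compound 1. For the compounds shown here, this is the first step that can be read at a single place, and its direction is downward, which the earlier compounds could not show. Nothing at hand bears on the origin of this step.

The compounds shown do not separate a contribution of the oxygen from one of chain length, a question that a butyl chain at the same carbon would address. On these data alone, how an amine or a carboxylic acid at the end of that chain would read also remains open.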